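Fluoro to methyl on the aryl ketone: meta variant

The source may report more compounds than this note shows. Statements on the series, on what has been measured and on what is new or still open speak of the compounds shown alone.

Compound 1 `O=C(/C=C/c1ccc2c(c1)B(O)OC2)c1ccc(F)cc1` gives 2800 nM in a functional assay on HCT-116 cells (Homo sapiens) for cytotoxicity, read by MTT assay, with a stated time of 48 h; a higher number here means a weaker inhibitor, a lower number a stronger inhibitor. Compound 2 `Cc1ccc(C(=O)/C=C/c2ccc3c(c2)B(O)OC3)cc1` gives 10500 nM in this assay, and compound 3 `O=C(/C=C/c1ccc2c(c1)B(O)OC2)c1cccc(F)c1` gives 6700 nM. The change from compound 1 to compound 2 is methyl in place of fluoro on an aromatic carbon, and it made a 3.8-fold higher number from compound 1 to compound 2 (0.57 log units; beyond the scatter). Compound 3 differs from compound 1 in 3-fluorophenyl in place of 4-fluorophenyl on a carbonyl carbon, with a 2.4-fold higher number from compound 1 to compound 3 (0.38 log units; beyond the scatter). Between compound 2 and compound 3 the step is a 1.6-fold lower number from compound 2 to compound 3 (0.20 log units; within the scatter).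

Compound 4 `Cc1cccc(C(=O)/C=C/c2ccc3c(c2)B(O)OC3)c1` is not yet measured. It differs from compound 3 in methyl in place of fluoro on an aromatic carbon. Within the data shown here, this is the same kind of change as the one from compound 1 to compound 2, but the place is not the same: there the group sits para to a large group, here meta to a large group. The change has one measured precedent among the compounds shown and recurs once unmeasured.

For compound 4 a step of about the same size is expected, a 3.0-fold higher number from compound 3 to compound 4 (0.47 log units; beyond the scatter), resting on the earlier step of a 3.8-fold higher number from compound 1 to compound 2 (0.57 log units; beyond the scatter), with the different place around the change leaving the transfer uncertain. Compound 4 is therefore estimated at 20000 nM, expected to lie between 8000 nM and 50000 nM.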

Compound 4, half-maximal inhibitory concentration: 6700 nM
The estimate for compound 4 lay 3.0-fold (0.47 log units) above the measured number; measured number outside the range, below it.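

In this assay, methyl in place of fluoro gives no change at the digits printed from compound 3 to compound 4 (within the scatter) on the 3-substituted phenyl ketone. This change does not carry over at a fixed size between the 4-substituted and the 3-substituted phenyl ketones: the same change on two cores in this assay, a 3.8-fold higher number (0.57 log units; beyond the scatter) from compound 1 to compound 2 and no change at the digits printed (within the scatter) from compound 3 to compound 4, 3.8-fold (0.57 log units) apart, beyond the scatter of two such steps

The other two new steps fit this reading: moving the methyl group gives a 1.6-fold lower number from compound 2 to compound 4 (0.20 log units; within the scatter), while changing both the group and its place gives a 2.4-fold higher number from compound 1 to compound 4 (0.38 log units; beyond the scatter), leaving compound 1 as the strongest of the four. The result shows that the step depends on where the change sits in this one pair of cases, but it does not explain the difference or show how the change would behave on another core.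

The compounds shown carry only fluoro and methyl on the phenyl ketone, so it remains open whether the lower number of compound 1 is specific to 4-fluorophenyl. Chloro, methoxy or an amine at the same places would test this.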